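Swapping the ring on the amide nitrogen of compound 2

This account rests on a few compounds, and the source may have more. Where it says the series, first, only, none or still open, it means among the compounds named here.

Compound 1, `Cc1ccc(S(=O)(=O)N2C=CNC(=O)[C@H]2CC(=O)NC2CCNc3ccccc32)cc1`, in an in vitro functional assay on cells for antagonist activity at B1 bradykinin receptor (Homo sapiens), read by luminescence and calcium flux, with a stated time of 2 h; a lower number here means a stronger inhibitor, a higher number a weaker inhibitor: 21.6 nM
Compound 2, `Cc1ccc(S(=O)(=O)N2C=CNC(=O)[C@H]2CC(=O)NC2CCCCC2C)cc1`, in this assay: 25.9 nM

Compound 2 stands level with compound 1 here, since a 1.2-fold higher number from compound 1 to compound 2 (0.08 log units; within the scatter). Compound 3, `CCN1CC[C@H](NC(=O)C[C@@H]2C(=O)NC=CN2S(=O)(=O)c2ccc(C)cc2)C(C)(C)C1`, is not yet measured. It differs from compound 2 in one place: a group of 10 heavy atoms (9 carbon, 1 nitrogen; one six-membered non-aromatic ring with 1 hetero atom) in place of a group of 7 heavy atoms (7 carbon; one six-membered non-aromatic ring of carbon only), on an amide-type nitrogen. The entering group brings one hydrogen-bond acceptor and one defined stereocentre, and its hetero atom is nitrogen. Among the compounds with values here, only one measured step bears on this: the step from compound 1 to compound 2 also swapped, on that same amide-type nitrogen, a larger group containing a six-membered ring with one hetero atom for the 2-methylcyclohexyl group, and a 1.2-fold higher number from compound 1 to compound 2 (0.08 log units; within the scatter). The present change goes the other way, back to a larger group containing a six-membered ring with one hetero atom. A step of no size beyond the scatter is therefore expected in this assay, so that a 1.0-fold lower number from compound 2 to compound 3 (0.02 log units; within the scatter). For compound 3 the estimate is 25 nM, ranging from 8 nM to 80 nM.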

Compound 3, half-maximal inhibitory concentration: 0.63 nM
Estimate against measurement, compound 3: 40-fold (1.60 log units) above, outside the stated range (below it).
By their numbers in this assay, from the lowest: compound 3; then compounds 1 and 2 (each within the scatter of the next).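

The position on the amide-type nitrogen looked indifferent when only compound 1 and compound 2 were known, but in this assay it proves highly responsive, with a 41-fold lower number from compound 2 to compound 3 (1.61 log units; beyond the scatter). The group in compound 3 also outperforms another group with the same heavy-atom count and a ring hetero atom, giving a 34-fold lower number from compound 1 to compound 3 (1.54 log units; beyond the scatter), so neither that count nor the presence of a ring hetero atom sets the number on its own. Nothing measured here explains why this group gives so much lower a number.

As far as these compounds go, the entering group's ring nitrogen, its other substituents and its defined stereocentre arrive together, so their separate contributions remain unknown. From the compounds shown here alone, it is also open how a simple open-chain amine or a carboxylic acid on this nitrogen would fare.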